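Swapping Cyclopropyl for Pyridylmethyl on the Amide Nitrogen

The source may hold more compounds than are shown below. What is called first, only, known or untested is meant among the compounds shown, and "the series" means these compounds.

Compound 1 `COc1cccc(OC)c1C(=O)Nc1c[nH]nc1C(=O)NC1CC1` is tested in an ADME assay on MRC5 cells (Homo sapiens) for inhibition, with a stated time of 72 h (on this read-out higher numbers stand for an effect only at larger amounts of compound and lower numbers for an effect already at smaller amounts), where compound 1 gives only a limit, > 50000 nM, and no number. Compound 2 `CO[C@H]1CC[C@H](NC(=O)c2n[nH]cc2NC(=O)c2cnc3ccccn23)CC1` gives 5900 nM in this assay, and compound 3 `CO[C@H]1CC[C@H](NC(=O)c2n[nH]cc2NC(=O)c2ccccc2F)CC1` gives 1000 nM; the step between them, a 5.9-fold lower number from compound 2 to compound 3 (0.77 log units; beyond the scatter), sits on a carbonyl carbon of the shared core. Compound 4 `COc1cccc(OC)c1C(=O)Nc1c[nH]nc1C(=O)NCc1ncccc1C` differs from compound 1 at another place: (3-methylpyridin-2-yl)methyl in place of cyclopropyl on an amide-type nitrogen. No measured step touches this amide-type nitrogen, so the change has no direct precedent among these three compounds. Since compound 1 sits at the limit of > 50000 nM in this assay, at which 1 of the 3 values shown sits, compound 4 is expected to stay near that limit, with a number no higher from compound 1 to compound 4 (the limit leaves the size open) meaning no shift beyond the scatter. The estimate for compound 4 is 50000 nM, between 20000 nM and 50000 nM.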

Compound 4, half-maximal effective concentration: > 50000 nM
Compound 4: only a limit was reported; the forecaster's own chance of this, stated with the estimate: 80%; the middle value lies on the limit itself.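

Compound 1 and compound 4 each give only a limit in this assay, so no step between them can be read: the limit of > 50000 nM in this assay, at which 2 of the 4 values shown sit.

The compounds shown leave open whether (3-methylpyridin-2-yl)methyl in place of cyclopropyl on the amide-type nitrogen changes the number at all, and by how much.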